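Plasma Protein Binding Across a Stereoisomer Pair

The source may hold more compounds than are shown below. What is called first, only, known or untested is meant among the compounds shown, and "the series" means these compounds.

Compound 1 `Cc1cn([C@H]2CCCN([C@H](CC(C)C)c3ccc(C(=O)O)c(Oc4cccc(Cl)c4)c3F)C2)c(=O)[nH]c1=O`: < 0.01
Compound 2 `CCC[C@H](c1ccc(C(=O)O)c(Oc2cccc(Cl)c2)c1F)N1CCC[C@H](n2cc(C)c(=O)[nH]c2=O)C1`: "not determined" (no result reported)
Compound 3 `CCC[C@H](c1ccc(C(=O)O)c(Oc2cccc(Cl)c2)c1OC)N1CCC[C@H](n2cc(C)c(=O)[nH]c2=O)C1`: "not determined" (no result reported)

In an ADME assay on a cell-free system (plasma, Mus musculus) for protein binding, using equilibrium dialysis, with a stated time of 5 h, tested at 10 uM (on this read-out lower numbers stand for a smaller free fraction and higher numbers for a larger free fraction), compound 1 gives < 0.01, which is a limit of the assay rather than a number (the limit of < 0.01 in this assay, at which 1 of the 3 values shown sits). Compound 2 has no result in this assay, and compound 3 likewise has none. Compound 4 `CCC[C@@H](c1ccc(C(=O)O)c(Oc2cccc(Cl)c2)c1F)N1CCC[C@H](n2cc(C)c(=O)[nH]c2=O)C1` differs from compound 2 as follows: the two compounds have the same atoms and bonds and differ only in configuration as drawn: 1 of 2 stereo elements differ; a stereocentre at a saturated chain carbon is drawn R in compound 2 and S in compound 4. Going by the values given here, no measured step between any two compounds exists, and compound 2 carries no value, so no size or direction can be expected for the change beyond the usual scatter. Compound 1 is the closest measured neighbour and its value is a limit. Compound 4 is expected to show a similarly small unbound fraction, estimated at 0.01 with a range from 0.003 to 0.03.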

Compound 4, unbound fraction: 0.007
Compound 4: the middle estimate sits 1.4-fold (0.15 log units) above what was measured; the measured number falls inside the stated range.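

No step can be read between compound 2 and compound 4, as compound 2 has no single number to compare. The compounds shown leave open whether the configuration at that saturated chain carbon shifts the unbound fraction in this assay.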